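This account rests on a few compounds, and the source may have more. Where it says the series, first, only, none or still open, it means among the compounds named here.

Working notes on a small series sharing one core.

Compound 1 `Cc1ccc(S(=O)(=O)NC(C2=CC(=O)c3c(O)ccc(O)c3C2=O)C(C)C)cc1` carries a sulfonamide on the core, but in a functional assay on HL-60 cells (Homo sapiens) for cytotoxicity, read by MTT assay (on this read-out lower numbers stand for stronger inhibition and higher numbers for weaker inhibition), compound 1 stands as "not determined" (no result reported); nothing can be said of it beyond its structure. For the measured compounds named here, compound 2 `Cc1ccccc1S(=O)(=O)NC(C1=CC(=O)c2c(O)ccc(O)c2C1=O)C(C)C` is the only member with a number: in this assay compound 2 gives 190 nM, and with compound 1 unreported this single value is the whole reference point, with no step between measured compounds available.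

Compound 3 `COc1ccc(S(=O)(=O)NC(C2=CC(=O)c3c(O)ccc(O)c3C2=O)C(C)C)c(OC)c1` differs from compound 2 only at the sulfonyl sulfur: 2,4-dimethoxyphenyl in place of 2-methylphenyl on a sulfonyl sulfur. Going by the values given here, there is no measured pair in this set that tests such a change, so the size of the step is unknown. The expectation is a step of a 1.3-fold higher number from compound 2 to compound 3 (0.12 log units; within the scatter) that stays within the scatter, with no direction claimed. Compound 3 is therefore estimated at 250 nM, in a range from 80 nM to 800 nM.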

Compound 3, half-maximal inhibitory concentration: 400 nM
Compound 3: the middle estimate sits 1.6-fold (0.20 log units) below what was measured; measured number inside the range.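

Placing 2,4-dimethoxyphenyl on the sulfonyl sulfur gives a 2.1-fold higher number from compound 2 to compound 3 (0.32 log units; beyond the scatter) in this assay, the first measured reading of any change at this position. For the compounds shown here, the direction is toward weaker inhibition, but the single step is modest, so this position accepts the larger aryl group with its two hydrogen-bond acceptors without loss of the cytotoxic read-out. Nothing measured here accounts for the step.

Going by these compounds alone, with compound 1 lacking a number, only this one pair can be read, and it cannot separate the effect of adding the methoxy groups from that of removing the methyl group. Also open, from the compounds shown here alone, is how the number would respond to a phenyl ring carrying a single methoxy group, an amine or a carboxylic acid, or to a longer alkyl chain on the sulfonyl sulfur.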